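Replacing an alkyl chain on the lactam oxygen with an aryl group

The compounds below may be only part of what the source reports. "The series", "measured", "known", "first", "only" and "open" are said of these compounds alone.

Measured compounds: compound 1 `CN1C[C@H](NC(=O)OCCCCC2CCCCC2)C1=O`, 1980 nM; compound 2 `COC(=O)N1C[C@H](NC(=O)OCCCCC2CCCCC2)C1=O`, 7180 nM; compound 3 `CC(=O)CCCON1C(=O)[C@@H](NC(=O)OCCCCC2CCCCC2)[C@@H]1C`, 75 nM.

In an assay on HEK293 cells for inhibition of N-acylethanolamine-hydrolyzing acid amidase (Homo sapiens), read by fluorescence, with stated times of 10 min and 50 min (on this read-out higher numbers stand for weaker inhibition and lower numbers for stronger inhibition), compound 3 gives the lowest of the three numbers, ahead of compound 1 and compound 2 by margins beyond the scatter. Compound 4 `C[C@H]1[C@H](NC(=O)OCCCCC2CCCCC2)C(=O)N1Oc1ccc(S(C)(=O)=O)cc1` differs from it by 4-(methylsulfonyl)phenyl in place of 3-acetylpropyl on an oxygen. Among the compounds with values here, the only measured step, a 3.6-fold higher number from compound 1 to compound 2 (0.56 log units; beyond the scatter), changes the ring nitrogen substituent and not this oxygen, so it bears on the new change only loosely, and the data give no direct precedent. A modest shift in either direction, or none beyond the scatter, is therefore expected, and compound 4 is estimated at 100 nM, within 25 nM to 400 nM, which would mean a 1.3-fold higher number from compound 3 to compound 4 (0.12 log units; within the scatter).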

Compound 4, half-maximal inhibitory concentration: 6 nM
Compound 4: middle estimate off by 17-fold (1.22 log units), on the high side; the measured number lies below the stated range.
By their numbers in this assay, from the lowest: compound 4; then compound 3; then compound 1; then compound 2.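

Putting 4-(methylsulfonyl)phenyl in place of 3-acetylpropyl on an oxygen whose other neighbour is the amide-type nitrogen in a ring gives a 13-fold lower number from compound 3 to compound 4 (1.10 log units; beyond the scatter) in this assay, a large step. The earlier compounds shown here showed no change on this oxygen; this step shows that the group there can move the number strongly and that an aromatic ring is tolerated. Nothing available explains the step. The compounds shown leave open whether the ring alone or the methylsulfonyl group carries it, which a plain phenyl would separate, and how an amine in place of the methylsulfonyl group would read.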